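Methoxy Added to the Phenoxy Ring of Compound 3

The source may report more compounds than this note shows. Statements on the series, on what has been measured and on what is new or still open speak of the compounds shown alone.

Compound 1 `CC(Nc1ccccc1Oc1cccc(F)c1)=C1C(=O)CC(c2ccccc2)CC1=O` gives 550 nM.
Compound 2 `COc1ccc(Oc2ccccc2NC(C)=C2C(=O)CC(c3ccccc3)CC2=O)cc1` gives 160 nM.
Compound 3 `CC(Nc1ccccc1Oc1ccccc1)=C1C(=O)CC(c2ccccc2)CC1=O` gives 79 nM.

In a functional assay on HeLa cells (Homo sapiens) for antiproliferative activity, read by cell counting, with a stated time of 3 days (a higher number here means a weaker inhibitor, a lower number a stronger inhibitor), compound 3 stands lowest of the three measured numbers: a 2.0-fold lower number from compound 2 to compound 3 (0.31 log units; beyond the scatter), and a 7.0-fold lower number from compound 1 to compound 3 (0.84 log units; beyond the scatter). Compound 4 `COc1cccc(Oc2ccccc2NC(C)=C2C(=O)CC(c3ccccc3)CC2=O)c1` differs from compound 3 by methoxy in place of hydrogen on an aromatic carbon. Going by the values given here, two measured steps bear on this change. Taking a substituent off the phenoxy ring lowered the number both times, a 7.0-fold lower number from compound 1 to compound 3 (0.84 log units; beyond the scatter) for fluoro and a 2.0-fold lower number from compound 2 to compound 3 (0.31 log units; beyond the scatter) for methoxy, so adding a methoxy back, here meta to a large group, is expected to raise the number by a modest step, a 2.5-fold higher number from compound 3 to compound 4 (0.40 log units; beyond the scatter). Compound 4 is therefore estimated at 200 nM, with a likely range from 80 nM to 500 nM.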

Compound 4, half-maximal inhibitory concentration: 93 nM
Beside the measured number, compound 4's estimate is 2.2-fold (0.33 log units) above it; low and high end bracket the measured number.
By their numbers in this assay, from the lowest: compounds 3, 4 and 2 (each within the scatter of the next, the first and the last beyond it); then compound 1.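

A methoxy at this place on the phenoxy ring makes no clear difference, with a 1.2-fold higher number from compound 3 to compound 4 (0.07 log units; within the scatter), and its two placements also cannot be told apart, with a 1.7-fold lower number from compound 2 to compound 4 (0.24 log units; within the scatter). At this same place, however, the choice of group does matter, since methoxy in place of fluoro gives a 5.9-fold lower number from compound 1 to compound 4 (0.77 log units; beyond the scatter). Nothing measured here explains that gap between fluoro and methoxy. On these data alone, it remains open whether a longer ethoxy chain, an amine or a carboxylic acid would fit the pattern of methoxy or of fluoro at this place.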